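Three inactive compounds and one still to test

A few compounds are considered here, and "the series" means these few. Any claim that something is new, unique, unknown or untested is made for them only; others in the source may bear on it.

Compound 1 `O=C(Nc1ccc(Nc2ncnc3[nH]ncc23)cc1)Nc1ccc(C(F)(F)F)cc1`: > 10000 nM
Compound 2 `COc1cccc(NC(=O)Nc2ccc(Oc3ncnc4[nH]ncc34)cc2)c1`: > 10000 nM
Compound 3 `Cc1cccc(NC(=O)Nc2ccc(Oc3ncnc4[nH]ncc34)cc2)c1C`: > 10000 nM

In a functional assay on HeLa cells (Homo sapiens) for inhibition, read by MTT assay, with a stated time of 72 h (a higher number here means a weaker inhibitor, a lower number a stronger inhibitor), compound 3 gives > 10000 nM, a limit of the assay and not a number. All three compounds share this position, as the limit of > 10000 nM in this assay, at which 3 of the 3 values shown sit, shows. Compound 4 `O=C(Nc1ccc(Oc2ncnc3[nH]ncc23)cc1)Nc1ccc(C(F)(F)F)cc1` has 4-(trifluoromethyl)phenyl in place of 2,3-dimethylphenyl on an amide-type nitrogen. For the measured compounds named here, the one measured step at this place is a step that the two limits leave unreadable from compound 2 to compound 3, so it offers no size to build on. Compound 1 carries the same 4-(trifluoromethyl)phenyl and gives > 10000 nM, also a limit. No step beyond the scatter is therefore expected, in either direction. The estimated change is a step that the limit leaves unreadable from compound 3 to compound 4. Compound 4 is expected to give about 15000 nM, with an estimated range of 6000 nM to 40000 nM.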

Compound 4, half-maximal inhibitory concentration: > 10000 nM
Compound 4: only a limit was reported (the forecaster's own chance of this, stated with the estimate: 75%); the middle value is on the limit's open side.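

Compound 4 gives only a limit, as do compound 1, compound 2 and compound 3, so none of the steps among them can be read. In this assay the compounds shown leave open whether any of these changes alters inhibition at all.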